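The source may report more compounds than this note shows. Statements on the series, on what has been measured and on what is new or still open speak of the compounds shown alone.

For the measured compounds named here, compound 1 `C#CCOC(=O)/C(C)=C/CC/C(C)=C/CC/C(C)=C/CC[C@@H]1[C@@]2(C)CCC(=O)C(C)(C)[C@H]2CC[C@@]1(C)O` is the one compound here with a definite number in a functional assay on DU-145 cells (Homo sapiens) for antiproliferative activity, read by MTT assay, with a stated time of 48 h; on this read-out lower numbers stand for stronger inhibition and higher numbers for weaker inhibition; compound 1 gives 46100 nM. In this assay compound 2 `C/C(=C\CC/C(C)=C/CC[C@@H]1[C@@]2(C)CCC(=O)C(C)(C)[C@H]2CC[C@@]1(C)O)CC/C=C(\C)C(=O)OCc1cn(-c2ccc(Br)cc2)nn1` gives only a limit, > 150000 nM. That pair yields an at least 3.2-fold higher number from compound 1 to compound 2 (0.51 log units; beyond the scatter). Compound 3 `C/C(=C\CC/C(C)=C/CC[C@@H]1[C@@]2(C)CCC(=O)C(C)(C)[C@H]2CC[C@@]1(C)O)CC/C=C(\C)C(=O)OCc1cn(-c2cccc(F)c2)nn1` departs from compound 1 through a closely related group: 1-(3-fluorophenyl)-1H-1,2,3-triazol-4-yl in place of ethynyl on a saturated chain carbon bound to an oxygen next to a carbonyl group. Going by the values given here, only that one measured step bears on this change, and it was at least modest, so a weakening beyond the scatter is expected in this assay for compound 3, roughly a 2.6-fold higher number from compound 1 to compound 3 (0.42 log units; beyond the scatter). Compound 3 is therefore estimated at 120000 nM, within 50000 nM to 300000 nM.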

Compound 3, half-maximal inhibitory concentration: > 150000 nM
Compound 3: only a limit was reported (the forecaster's own chance of this, stated with the estimate: 45%); middle value at least 1.2-fold (0.09 log units) from the limit.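

Replacing ethynyl with 1-(3-fluorophenyl)-1H-1,2,3-triazol-4-yl gives an at least 3.2-fold higher number from compound 1 to compound 3 (0.51 log units; beyond the scatter) in this assay, so the weakening seen with the 4-bromophenyl group of compound 2 recurs with a second aryl group at this position. Compound 2 and compound 3 both stand at a limit, not a number: the limit of > 150000 nM in this assay, at which 2 of the 3 values shown sit.

The step from compound 2 to compound 3 cannot be read, so 3-fluorophenyl and 4-bromophenyl cannot be ranked. The compounds shown leave open whether the triazole itself or its aryl group goes with the weakening, and how a triazole carrying an amine or a short alkyl chain instead of the aryl ring would behave in this assay.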